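Substituting the indole nitrogen: a basic side chain enters

The source may hold more compounds than are shown below. What is called first, only, known or untested is meant among the compounds shown, and "the series" means these compounds.

Among the compounds with values here, compound 2 `O=C1c2c[n+]([O-])c3ccccc3c2C(=O)c2[nH]c3ccccc3c21` gives 320 nM in a functional assay on A549 cells (Homo sapiens) for cytotoxicity, read by MTT assay, with a stated time of 72 h (a higher number here means a weaker inhibitor, a lower number a stronger inhibitor), and stands within the scatter of the only other number, that of compound 1 `O=C1c2c[n+]([O-])c3ccccc3c2C(=O)c2c1c1ccccc1n2Cc1cn(C[C@@H](O)CO)nn1`, which gives 390 nM. Within the data shown here, the one measured step, a 1.2-fold lower number from compound 1 to compound 2 (0.09 log units; within the scatter), shows that a substituent on this aromatic nitrogen changed little. Compound 3 `O=C1c2c[n+]([O-])c3ccccc3c2C(=O)c2c1c1ccccc1n2CCCCN1CCNCC1` differs from compound 2 by 4-(piperazin-1-yl)butyl in place of hydrogen on an aromatic nitrogen. Because a 1.2-fold lower number from compound 1 to compound 2 (0.09 log units; within the scatter) stayed within the scatter, the step of no change at the digits printed from compound 2 to compound 3 (within the scatter) is likewise expected to be small. Compound 3 is therefore estimated at 320 nM, expected between 100 nM and 1000 nM.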

Compound 3, half-maximal inhibitory concentration: 540 nM
For compound 3 the middle estimate is 1.7-fold (0.23 log units) below the measured one, within the range that was stated.
By their numbers in this assay, from the lowest: compounds 2, 1 and 3 (each within the scatter of the next).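

In this assay, a second, quite different substituent on the aromatic nitrogen, 4-(piperazin-1-yl)butyl, also stays within the scatter of the unsubstituted compound, with a 1.7-fold higher number from compound 2 to compound 3 (0.23 log units; within the scatter). Exchanging 1-(2,3-dihydroxypropyl)-1H-1,2,3-triazol-4-yl for 3-(piperazin-1-yl)propyl on the saturated chain carbon gives a 1.4-fold higher number from compound 1 to compound 3 (0.14 log units; within the scatter), so this position has so far accepted both substituents without a step beyond the scatter. No measurement at hand explains this. Going by these compounds, it remains open whether a morpholine, a terminal carboxylic acid or a much longer chain at this nitrogen would behave the same way.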